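The source may report more compounds than this note shows. Statements on the series, on what has been measured and on what is new or still open speak of the compounds shown alone.

Working notes on the series. The series is followed in an assay on isolated protein for binding affinity to melatonin receptor type 1B (Homo sapiens); a lower number here means a stronger inhibitor, a higher number a weaker inhibitor. Compound 1, `CCCC(=O)Nc1ccc(C(=O)c2cccc(OC)c2)cc1`, gives 33 nM in this assay. Compound 2, `CCCC(=O)Nc1ccc(Nc2cccc3c2CCO3)cc1`, gives 39 nM in this assay. Going by the values given here, the two numbers lie within the scatter of each other, so the data give no order between compound 1 and compound 2; compound 2 is simply one of two closely matched points, and no step between the two measured compounds is recorded.

Compound 3, `CCCC(=O)Nc1ccc(N(C)c2cccc3c2CCO3)cc1`, is not yet measured in this assay. It differs from compound 2 only in one place: methyl in place of hydrogen on a nitrogen on an aromatic ring. The change is small in size, and nothing in the measured pair speaks to what replacing the amine hydrogen by a methyl does here. Among the compounds with values here, with no measured step to lean on, the expectation is for a step from compound 2 to compound 3 that is small and most likely a slight weakening, that is a 1.7-fold higher number from compound 2 to compound 3 (0.22 log units; within the scatter), though a result within the scatter of compound 2 is fully open. The estimate for compound 3 in this assay is therefore 65 nM, with a range from 15 nM to 280 nM.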

Compound 3, inhibition constant: 0.49 nM
For compound 3 the middle estimate is 130-fold (2.12 log units) above the measured one, and the stated range ends above it.
By their numbers in this assay, from the lowest: compound 3; then compounds 1 and 2 (each within the scatter of the next).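

In this assay, methyl in place of hydrogen on a nitrogen on an aromatic ring gives an 80-fold lower number from compound 2 to compound 3 (1.90 log units; beyond the scatter), so a single added carbon at this nitrogen moves the number far beyond the scatter. The earlier pair could not show this: compound 1 and compound 2 differ in more than one place and lie within the scatter of each other, so neither value said anything about this nitrogen taken alone. No measurement at hand bears on what lies behind a step of this size.

From the compounds shown here alone, whether the lower number is particular to methyl remains open, since an ethyl group, a longer chain or an acetyl group on the same nitrogen would be needed to show how much room this position allows. Going by these compounds, it is also open whether the step carries over to other compounds, for example one with a cyclopropyl group in place of the chain on the amide carbonyl.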